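Toward compound 4: a nitro group for a ring hydrogen

The source may hold more compounds than are shown below. What is called first, only, known or untested is meant among the compounds shown, and "the series" means these compounds.

Measured so far:
compound 1 `O=C(Nc1ccccc1)C(Cl)Cl` — "not determined" (no result reported)
compound 2 `O=C(Nc1ccccc1[N+](=O)[O-])C(Cl)Cl` — 194000 nM
compound 3 `O=C(Nc1cccc(Cl)c1)C(Cl)Cl` — 44500 nM

In a functional assay on Bel-7402 cells (Homo sapiens) for antiproliferative activity, read by MTT assay, with a stated time of 72 h (on this read-out higher numbers stand for weaker inhibition and lower numbers for stronger inhibition), compound 1 stands without a number: its entry reads "not determined" (no result reported). Its two substituted relatives do carry values. In this assay compound 2 gives 194000 nM, and compound 3 gives 44500 nM. Going by the values given here, these two differ from each other in more than one place, so no step between them is given; their values can only be set side by side, and both lie in the region of weak inhibition.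

Compound 4 `O=C(Nc1cccc([N+](=O)[O-])c1)C(Cl)Cl` differs from compound 1 by nitro in place of hydrogen on an aromatic carbon. As far as these compounds go, because compound 1 has no value, the size of this step in this assay cannot be computed; the sense of its direction must remain open, and a change beyond the scatter cannot be claimed either way.

In this assay compound 4 is estimated at 80000 nM, with a range from 20000 nM to 300000 nM. This estimate rests on compound 2 with 194000 nM and on compound 3 with 44500 nM, both weak, and expects compound 4 to fall in the same weak region.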

Compound 4, half-maximal inhibitory concentration: 15700 nM
Compound 4: the middle estimate sits 5.1-fold (0.71 log units) above what was measured; measured number below the stated range.
By their numbers in this assay, from the lowest: compound 4; then compound 3; then compound 2.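

In this assay, going by these compounds alone, the aromatic carbon that carries chloro in compound 3 also takes nitro, and this exchange gives a 2.8-fold lower number from compound 3 to compound 4 (0.45 log units; beyond the scatter) and is the first change at a single place that can be read in this set. It shows that the number responds to which group sits on this carbon, though the response is modest and compound 4 gives 15700 nM and remains a weak inhibitor. No measured evidence is available to account for the difference between these two groups.

Compound 1 has no number, so the steps from it, including the one that adds the nitro group, cannot be read. Also open, as far as these compounds go, is whether an amine or a carboxylic acid on this same aromatic carbon would move the number further, and in which direction.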